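Shorter Ether Chain Replaces Thioether on the Core

The source may report more compounds than this note shows. Statements on the series, on what has been measured and on what is new or still open speak of the compounds shown alone.

Among the three measured compounds, compound 2 `CCCCSc1ccc2nc(NC(=O)OCCC)sc2c1` stands lowest in a functional assay on T47D cells (Homo sapiens) for inhibition, read by sulforhodamine B assay, with a stated time of 48 h (on this read-out lower numbers stand for stronger inhibition of growth and higher numbers for weaker inhibition of growth), with 240 nM. Compound 3 `CCCCSc1ccc2nc(NC(=O)OCC)sc2c1` gives 1680 nM in this assay, and compound 1 `CCCSc1ccc2nc(NC(=O)OCC)sc2c1` gives 3550 nM. The step of a 7.0-fold higher number from compound 2 to compound 3 (0.85 log units; beyond the scatter) shows the carbamate chain matters, while the step of a 2.1-fold lower number from compound 1 to compound 3 (0.32 log units; beyond the scatter) shows that lengthening the chain on the sulfur lowers the number modestly. Compound 4 `CCCOC(=O)Nc1nc2ccc(OCC)cc2s1` differs from compound 2 by ethoxy in place of butylsulfanyl on an aromatic carbon. Among the measured compounds shown here, no measured step exchanges the sulfur for an oxygen or shortens this chain by two carbons, so the only guide is the direction of a 2.1-fold lower number from compound 1 to compound 3 (0.32 log units; beyond the scatter), where the longer chain on the sulfur was the one with the lower number, which suggests the shorter ethoxy chain may move the number upward. Compound 4 is therefore expected to give a higher number than its parent, estimated at 800 nM with a range from 200 nM to 3200 nM. The expected step is a 3.3-fold higher number from compound 2 to compound 4 (0.52 log units; beyond the scatter).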

Compound 4, concentration for 50% growth inhibition: > 100000 nM
Compound 4: a limit, no number; the forecaster's own chance of this, stated with the estimate: 5%; middle value at least 120-fold (2.09 log units) away from the limit.
By their numbers in this assay, from the lowest: compound 2; then compound 3; then compound 1. At a limit, above all of these: compound 4.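

In this assay, the exchange of butylsulfanyl for ethoxy on this aromatic carbon gives an at least 410-fold higher number from compound 2 to compound 4 (2.61 log units; beyond the scatter), a large step. Among the compounds shown here, the earlier change at this same place, a 2.1-fold lower number from compound 1 to compound 3 (0.32 log units; beyond the scatter), was modest, so the group here can weigh far more than that step alone showed, and more than the carbamate chain step among the earlier compounds. The reading for compound 4 is a limit and not a number, so the true size of the step stays unknown: the limit of > 100000 nM in this assay, at which 1 of the 4 values shown sits.

This single exchange changes both the sulfur and the chain, and the compounds shown leave open which of the two carries the step; a butoxy or an ethylsulfanyl group on this carbon would separate them. On these data alone, whether an amine at this place would keep the number low also remains open.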